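Swapping One Group on Compound 2

A few compounds are considered here, and "the series" means these few. Any claim that something is new, unique, unknown or untested is made for them only; others in the source may bear on it.

Doses measured so far in a functional assay on the whole organism for inhibition, with Mus musculus as the target (a lower number here means that less compound is needed, a higher number that more compound is needed for the effect), are these.

Compound 1 `CN1Cc2c(N)cccc2C(c2ccc(Cl)cc2)C1` gives 1.1 mg/kg
Compound 2 `CCCNC(=O)Nc1cccc2c1CN(C)CC2c1ccccc1` gives > 80 mg/kg (a limit, not a number)
Compound 3 `CCOC(=O)Nc1cccc2c1CN(C)CC2c1ccc(F)cc1` gives 3.3 mg/kg

Compound 2 stands at > 80 mg/kg in this assay, and this is a limit of the assay, not a true number. Compound 4 (`CCCCNCCC(=O)Nc1cccc2c1CN(C)CC2c1ccccc1`) has not been measured yet. It keeps the core of compound 2 and changes one group. The change is 2-(butylamino)ethyl in place of propylamino on a carbonyl carbon and reads in words as 2-(butylamino)ethyl in place of propylamino on a carbonyl carbon.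

Among the compounds with values here, no measured pair shows what such a swap does, so any expectation here is loose. Compound 1 gives 1.1 mg/kg and compound 3 gives 3.3 mg/kg as true numbers, which makes a true number for compound 4 seem likely. The expected change is an at least 6.6-fold lower number from compound 2 to compound 4 (0.82 log units; beyond the scatter) towards a lower dose, beyond the usual scatter, and its size stays uncertain: the starting point is only a limit. For compound 4 the estimated dose is 12 mg/kg with 2 mg/kg to 70 mg/kg as its expected range.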

Compound 4, dose for half-maximal effect: 74 mg/kg
For compound 4 the middle estimate is 6.2-fold (0.79 log units) below the measured one; the whole stated range lies below it.
By their numbers in this assay, from the lowest: compound 1; then compound 3; then compound 4. At a limit, above all of these: compound 2.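

Within the data shown here, on this carbonyl carbon, the swap of propylamino for 2-(butylamino)ethyl gives the first change that can be read at this place, and in this assay it comes out as an at least 1.0-fold lower number from compound 2 to compound 4 (0.03 log units; that floor lies within the scatter). Compound 4 gives 74 mg/kg, a true number, so this longer group leaves a dose that can be stated, although a high one compared with the other true numbers shown. Compound 2 holds only a limit of the assay, not a number: the limit of > 80 mg/kg in this assay, at which 1 of the 4 values shown sits.

From the compounds shown here alone, the real size of the change therefore stays unknown, and the step alone cannot show that the swap lowers the dose at all. Also open, going by these compounds, is whether a shorter chain, a longer chain or a carboxylic acid on this carbonyl carbon would give a clearly lower dose than compound 4 does.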